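Hydrogen in place of methoxy: what to expect

This account rests on a few compounds, and the source may have more. Where it says the series, first, only, none or still open, it means among the compounds named here.

Compound 1 `COc1cc(/C=N/NC(=O)c2ccncc2)cc(OC)c1O`: 34%
Compound 2 `COc1cc(/C=N/NC(=O)c2ccncc2)cc(O)c1O`: 41%

In a functional assay on cells (Mus musculus) for cytotoxicity, read by MTT assay, with a stated time of 24 h, tested at 1 uM (on this read-out lower numbers stand for a weaker effect and higher numbers for a stronger effect at the one concentration tested), compound 1 gives 34% and compound 2 gives 41%. Compound 2 thus stands on the larger of the two numbers, but the step of a number 7 percentage points higher from compound 1 to compound 2 (within the scatter) is within the scatter, so the two cannot be told apart on this evidence. Compound 3 `O=C(N/N=C/c1ccc(O)c(O)c1)c1ccncc1` differs from compound 2 by hydrogen in place of methoxy on an aromatic carbon. Within the data shown here, the one measured step bears on it only loosely: it exchanged hydrogen for methyl on an oxygen on an aromatic ring and was within the scatter, whereas here a whole methoxy leaves. Among the measured compounds shown here, no measured step removes a methoxy, so there is no basis for expecting a shift beyond the scatter in this assay in either direction. Compound 3 is therefore expected to give 38%, within 20% to 58%, a step of a number 3 percentage points lower from compound 2 to compound 3 (within the scatter) that is expected to stay inside the scatter.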

Compound 3, a percentage reported as activity, at one concentration (the size of the read-out at that concentration, not a potency) in the Mus musculus assay: 84%
The estimate for compound 3 lay 46 percentage points below the measured number; the measured number lies above the stated range.
By their numbers in the Mus musculus assay, from the lowest: compounds 1 and 2 (each within the scatter of the next); then compound 3.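

At this carbon, ortho to a hydroxy group and meta to a hydroxy group, the exchange of methoxy for hydrogen counts for much more than the earlier change on the oxygen. In the Mus musculus assay that earlier change gave a number 7 percentage points higher from compound 1 to compound 2 (within the scatter), whereas the loss of the whole methoxy gave a number 43 percentage points higher from compound 2 to compound 3 (beyond the scatter). The same pair also moves toward a stronger effect in a physicochemical assay on cells (Homo sapiens), with a stated time of 18 h, tested at 1 uM (on this read-out lower numbers stand for a stronger effect and higher numbers for a weaker effect at the one concentration tested), where compound 2 gives 59% and compound 3 gives 19%: the measured a percentage reported as activity, at one concentration (the size of the read-out at that concentration, not a potency) of compound 2, 59%, and of compound 3, 19%, a number 40 percentage points lower (beyond the scatter)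

The compounds shown leave open whether the gain in the Mus musculus assay needs hydrogen at this carbon or would survive a fluorine atom, an amine or an ethoxy group there. Among these compounds, they also leave open whether the two read-outs would keep moving together across such groups, since only this one pair links them.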